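The source may report more compounds than this note shows. Statements on the series, on what has been measured and on what is new or still open speak of the compounds shown alone.

In an ADME assay on HepG2 2.2.15 cells (Homo sapiens) for cytotoxicity (on this read-out higher numbers stand for lower toxicity in this test and lower numbers for higher toxicity in this test), compound 1 `CCCCCCCC(=O)OCCc1c(-c2ccccc2Cl)c2cc(Cl)ccc2[nH]c1=O` gives 78000 nM. Compound 2 `O=C(OCCc1c(-c2ccccc2Cl)c2cc(Cl)ccc2[nH]c1=O)c1cccs1` is reported as > 1700000 nM, which is a limit of this assay and not a number. Compound 3 `O=C(/C=C/c1cccc(F)c1)OCCc1c(-c2ccccc2Cl)c2cc(Cl)ccc2[nH]c1=O` keeps everything else but carries 2-(3-fluorophenyl)ethenyl in place of thiophen-2-yl on a carbonyl carbon. Among the compounds with values here, only one measured step changes the same place, and it is large: an at least 21-fold higher number from compound 1 to compound 2 (1.33 log units; beyond the scatter). It shows that a swap at this place in compound 2 can move the read-out far, but it involves a different incoming group, so it is only a loose guide. A drop toward the number of compound 1 78000 nM is expected, though not all the way. The expected change is an at least 5.6-fold lower number from compound 2 to compound 3 (0.75 log units; beyond the scatter), and it points to lower numbers, meaning higher toxicity in this test. For compound 3 the estimate is 300000 nM, with an expected range from 60000 nM to 1700000 nM.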

Compound 3, half-maximal cytotoxic concentration: > 1600000 nM
Compound 3: a limit, no number (the forecaster's own chance of this, stated with the estimate: 35%); middle value at least 5.3-fold (0.72 log units) away from the limit.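

In this assay compound 3 also gives a limit of the assay and not a number, > 1600000 nM. Putting 2-(3-fluorophenyl)ethenyl in place of heptyl on a carbonyl carbon gives an at least 20-fold higher number from compound 1 to compound 3 (1.31 log units; beyond the scatter), which means lower toxicity in this test, so the large change seen with thiophen-2-yl is not tied to that one group. The step between the two limits cannot be read, and thiophen-2-yl and 2-(3-fluorophenyl)ethenyl cannot be ranked against each other.

On these data alone, how far the true values of compound 2 and compound 3 lie past their limits stays unknown. As far as these compounds go, it also stays open whether the lower number of compound 1 belongs to the long heptyl chain alone, or would also appear with a shorter butyl chain or a group carrying an amine on this carbonyl carbon.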